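Swapping Trifluoromethyl for Methylsulfanyl: Expected Effect on Tolerance

The source may report more compounds than this note shows. Statements on the series, on what has been measured and on what is new or still open speak of the compounds shown alone.

Of the compounds shown here, three have been tested in an ADME assay on MDCK cells (Canis lupus familiaris) for cytotoxicity; a higher number here means that more compound is tolerated, a lower number that less compound is tolerated. Compound 1 `O=[N+]([O-])C1=NNc2nc(C(F)(F)F)nn2C1c1ccc(O)c(O)c1` gives 183000 nM. Compound 2 `O=[N+]([O-])C1=NNc2nc(C(F)(F)F)nn2C1c1c(O)cc(O)cc1O` gives 252000 nM in this assay. Compound 3 `CSc1nc2n(n1)C(c1ccc(O)c(O)c1)C([N+](=O)[O-])=NN2` gives 362000 nM in this assay. Compound 3 differs from compound 1 in one place: methylsulfanyl in place of trifluoromethyl on an aromatic carbon. That change brought a 2.0-fold higher number from compound 1 to compound 3 (0.30 log units; within the scatter), a step that stays inside the ordinary spread of repeated measurements. Compounds 1 and 2 carry different cores, and the difference between the two cores is not broken down here; their values in this assay also lie within the scatter of each other. Compound 4 `CSc1nc2n(n1)C(c1c(O)cc(O)cc1O)C([N+](=O)[O-])=NN2` has not yet been measured. It stands to compound 2 as compound 3 stands to compound 1: methylsulfanyl in place of trifluoromethyl on an aromatic carbon, at exactly the same kind of position, so this is the same change carried out on the core of compound 2. Because the measured step was a 2.0-fold higher number from compound 1 to compound 3 (0.30 log units; within the scatter), a step of about the same size is expected here, namely a 1.9-fold higher number from compound 2 to compound 4 (0.28 log units; within the scatter). Compound 4 is therefore estimated at 480000 nM, with a likely range from 230000 nM to 1000000 nM.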

Compound 4, half-maximal cytotoxic concentration: 877000 nM
For compound 4 the middle estimate is 1.8-fold (0.26 log units) below the measured one, and the stated range covers the measured number.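

The same swap of trifluoromethyl for methylsulfanyl, carried onto a second core, gave a 3.5-fold higher number from compound 2 to compound 4 (0.54 log units; beyond the scatter) in this assay. The change went the same way on both cores, and the two step sizes cannot be told apart: the same change on two cores in this assay, a 2.0-fold higher number (0.30 log units; within the scatter) from compound 1 to compound 3 and a 3.5-fold higher number (0.54 log units; beyond the scatter) from compound 2 to compound 4, 1.8-fold (0.25 log units) apart, within the scatter of two such steps. So, for these two cores, the step carried over in direction and roughly in size, but the earlier step on its own lies within the scatter, and a pair of cores does not show that the change would behave alike on any other core, nor why the number goes up.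

The compounds shown leave open how other groups in the same place, such as an amine, a methoxy group or a longer chain like ethylsulfanyl, would compare in this assay. Also open, from the compounds shown here alone, is whether the same step would appear on a core carrying a carboxylic acid in place of the hydroxyl groups.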